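The source may report more compounds than this note shows. Statements on the series, on what has been measured and on what is new or still open speak of the compounds shown alone.

Compound 2 `CC1(c2ccccc2)ON=C(c2ccc([N+](=O)[O-])s2)O1` was examined in an ADME assay on Vero cells (Chlorocebus sabaeus) for cytotoxicity, read by sulforhodamine B assay, with a stated time of 72 h; on this read-out lower numbers stand for stronger inhibition and higher numbers for weaker inhibition. In this assay compound 2 gives < 180000 nM, which is a limit of the assay rather than a number. Its closest relative, compound 1 `O=[N+]([O-])c1ccc(C2=NOC(c3ccccc3)O2)s1`, differs only by carrying a hydrogen where compound 2 carries a methyl on the saturated ring carbon. In this assay compound 1 likewise gives < 180000 nM, again a limit. The step that the two limits leave unreadable from compound 1 to compound 2 cannot be read because the limit of < 180000 nM in this assay, at which 2 of the 2 values shown sit, holds both values. Compound 3 `CC1(c2ccc(Cl)cc2)ON=C(c2ccc([N+](=O)[O-])s2)O1` is the next variation: chloro in place of hydrogen on an aromatic carbon. For the measured compounds named here, no measured step bears on this particular change, since the only step available is itself unreadable. With both known values at a limit, the step that the limit leaves unreadable from compound 2 to compound 3 is expected to stay within scatter, most likely returning the same limit. The estimate for compound 3 in this assay is 100000 nM, with a range from 20000 nM to 180000 nM.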

Compound 3, half-maximal inhibitory concentration: < 180000 nM
Compound 3: a limit, no number; the forecaster's own chance of this, stated with the estimate: 70%; the middle value is on the limit's open side.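

For the compounds shown here, neither the step from compound 1 to compound 2 nor the one from compound 2 to compound 3 can be read, since each value is a limit and not a number: the limit of < 180000 nM in this assay, at which 3 of the 3 values shown sit. The compounds shown leave open what the actual values are in this assay, and whether the methyl or the chloro changes them at all.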